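The source may hold more compounds than are shown below. What is called first, only, known or untested is meant among the compounds shown, and "the series" means these compounds.

Values measured in a functional assay on HCT-116 cells (Homo sapiens) for cytotoxicity, read by MTT assay, with a stated time of 48 h; a lower number here means a stronger inhibitor, a higher number a weaker inhibitor:
- Compound 1 `CN1CC(c2ccc(Cl)cc2)[C@@]2(NC(=S)N(c3ccc(F)c(Cl)c3)C2=O)[C@@]12C(=O)Nc1ccc(Br)cc12`: 9900 nM
- Compound 2 `CC(C)Oc1ccc(C2CN(C)[C@]3(C(=O)Nc4ccc(Br)cc43)[C@]23NC(=S)N(c2ccc(F)c(Cl)c2)C3=O)cc1`: 38800 nM
- Compound 3 `CCOc1ccc(N2C(=O)[C@@]3(NC2=S)C(c2ccc(Cl)cc2)CN(C)[C@]32C(=O)Nc3ccc(Br)cc32)cc1`: >= 50000 nM, which is a limit of the assay and not a number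

Compound 1 has the lower of the two actual numbers, so it is the best starting point here. Compound 4 `CN1CC(c2ccc(Cl)cc2)[C@@]2(NC(=S)N(c3ccc(F)c(Cl)c3)C2=O)[C@@]12C(=O)Nc1ccccc12` has hydrogen in place of bromo on an aromatic carbon. Among the measured compounds shown here, no measured step changes this place, so the evidence is only indirect. The changes elsewhere gave a 3.9-fold higher number from compound 1 to compound 2 (0.59 log units; beyond the scatter) and an at least 5.0-fold higher number from compound 1 to compound 3 (0.70 log units; beyond the scatter). Both moved away from compound 1 towards higher numbers, so a modest rise is expected here too, though its size is uncertain. The expected change is a 2.2-fold higher number from compound 1 to compound 4 (0.35 log units; beyond the scatter). For compound 4 the estimated value is 22000 nM, with an expected range of 8000 nM to 50000 nM.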

Compound 4, half-maximal inhibitory concentration: 7780 nM
The estimate for compound 4 lay 2.8-fold (0.45 log units) above the measured number; measured number outside the range, below it.
By their numbers in this assay, from the lowest: compounds 4 and 1 (each within the scatter of the next); then compound 2. At a limit, above all of these: compound 3.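

Hydrogen in place of bromo on this aromatic carbon gives a 1.3-fold lower number from compound 1 to compound 4 (0.10 log units; within the scatter) in this assay. Unlike the two changes made elsewhere on compound 1, this one leaves the two numbers level, so the bromo is not needed to keep the cytotoxicity of compound 1 in this assay. No measurement shown explains this result.

As far as these compounds go, only bromo and hydrogen appear at this position, so it remains open whether a larger or different group, such as an amine or a carboxylic acid, would move the number beyond the scatter.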